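Swapping the Anilino Ring of a Chalcone-Thiazole Core

A few compounds are considered here, and "the series" means these few. Any claim that something is new, unique, unknown or untested is made for them only; others in the source may bear on it.

Three compounds built on a shared core have been compared in a functional assay on BGC-823 cells (Homo sapiens) for cytotoxicity, read by MTT assay; a lower number here means a stronger inhibitor, a higher number a weaker inhibitor. Compound 1 `COc1ccc(/C=C/C(=O)c2sc(Nc3ccc(Cl)cc3)nc2C)cc1` stands apart: in this assay compound 1 reports only a limit, > 25000 nM, rather than a number (the limit of > 25000 nM in this assay, at which 1 of the 3 values shown sits). Compound 2 `Cc1nc(Nc2ccc(Cl)c(Cl)c2)sc1C(=O)/C=C/c1ccccc1` gives 10600 nM in this assay. Compound 3 `COc1cc(/C=C/C(=O)c2sc(Nc3ccc(F)c(Cl)c3)nc2C)cc(OC)c1OC` gives 9700 nM in this assay, the lowest of the two numbers, though its gap to compound 2 lies within the scatter of repeated measurements, so no order between these two can be read. Among the compounds with values here, no pair of the measured compounds differs in one place only, so no measured step is available.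

Compound 4 `COc1cc(/C=C/C(=O)c2sc(Nc3cccc(C)c3)nc2C)cc(OC)c1OC` has not yet been tested. It differs from compound 3 in a single respect: 3-methylphenyl in place of 3-chloro-4-fluorophenyl on a nitrogen on an aromatic ring. Within the data shown here, no measured pair shows what such an exchange on the nitrogen does in this assay, so the expectation rests on compound 3 with its 9700 nM and on the spread of the other values. The step from compound 3 to compound 4 is expected to be a 1.5-fold higher number from compound 3 to compound 4 (0.19 log units; within the scatter), a slight shift toward a weaker inhibitor that need not exceed the scatter. Compound 4 is therefore estimated at 15000 nM, with a range of 5000 nM to 50000 nM.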

Compound 4, half-maximal inhibitory concentration: 17200 nM
Beside the measured number, compound 4's estimate is 1.1-fold (0.06 log units) below it, within the range that was stated.
By their numbers in this assay, from the lowest: compounds 3, 2 and 4 (each within the scatter of the next). At a limit, above all of these: compound 1.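

Within the data shown here, this exchange gives the first single-place step on the shared core: in this assay, the change to 3-methylphenyl on the nitrogen gives a 1.8-fold higher number from compound 3 to compound 4 (0.25 log units; within the scatter). At this position, then, a ring with chlorine and fluorine and a ring with a methyl group and no halogen are not told apart by this assay, and the 3-chloro-4-fluorophenyl group is not shown to be required for the number of compound 3. Nothing measured here speaks to a cause for this small step.

On these data alone, whether a group of another kind on this nitrogen, such as a 4-carboxyphenyl or a pyridinyl ring, would move the number beyond the scatter stays open. As far as these compounds go, what the three methoxy groups shared by compound 3 and compound 4 contribute also stays open.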